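This account rests on a few compounds, and the source may have more. Where it says the series, first, only, none or still open, it means among the compounds named here.

Compound 3 `CN1[C@@H]2c3[nH]c4ccccc4c3C[C@H]1[C@H](C#N)N1[C@@H](CNC(=O)/C=C/c3cccc(C(F)(F)F)c3)c3[nH]c4ccccc4c3C[C@@H]21` carries the highest number of the three measured compounds in a functional assay on HCT-116 cells (Homo sapiens) for cytotoxicity, read by MTT assay, with a stated time of 72 h (on this read-out higher numbers stand for weaker inhibition and lower numbers for stronger inhibition), giving 610 nM; compound 1 `COc1ccc(C(=O)NC[C@H]2c3[nH]c4ccccc4c3C[C@H]3[C@H]4c5[nH]c6ccccc6c5C[C@@H]([C@H](C#N)N23)N4C)cc1` gives 430 nM and compound 2 `CN1[C@@H]2c3[nH]c4ccccc4c3C[C@H]1[C@H](C#N)N1[C@@H](CNC(=O)c3cc4ccccc4o3)c3[nH]c4ccccc4c3C[C@@H]21` gives 330 nM. Compound 4 `CN1[C@@H]2c3[nH]c4ccccc4c3C[C@H]1[C@H](C#N)N1[C@@H](CNC(=O)/C=C/c3ccccc3)c3[nH]c4ccccc4c3C[C@@H]21` differs from compound 3 by hydrogen in place of trifluoromethyl on an aromatic carbon. Among the compounds with values here, no measured step shows this exact change; the nearest comparisons exchange the whole group on the carbonyl carbon, a 1.4-fold higher number from compound 1 to compound 3 (0.15 log units; within the scatter) and a 1.8-fold higher number from compound 2 to compound 3 (0.27 log units; within the scatter), both within the scatter. Since every exchange seen so far leaves this assay essentially unchanged, no step beyond the scatter is expected for a 1.0-fold lower number from compound 3 to compound 4 (0.01 log units; within the scatter). Compound 4 is therefore estimated at 600 nM, within a range of 250 nM to 1500 nM.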

Compound 4, half-maximal inhibitory concentration: 1960 nM
Beside the measured number, compound 4's estimate is 3.3-fold (0.51 log units) below it; measured number above the stated range.
By their numbers in this assay, from the lowest: compounds 2, 1 and 3 (each within the scatter of the next); then compound 4.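

In this assay, the loss of trifluoromethyl alone moves the number beyond the scatter (a 3.2-fold higher number from compound 3 to compound 4 (0.51 log units; beyond the scatter)), so this aromatic carbon responds to a change, whereas exchanges of the whole group on the carbonyl carbon among compound 1, compound 2 and compound 3 stayed within it. The unsubstituted 2-phenylethenyl group also stands apart from 1-benzofuran-2-yl (a 5.9-fold higher number from compound 2 to compound 4 (0.77 log units; beyond the scatter)) and from 4-methoxyphenyl (a 4.6-fold higher number from compound 1 to compound 4 (0.66 log units; beyond the scatter)). Nothing measured here explains the effect of trifluoromethyl. On these data alone, whether a chlorine atom or an amine on the same aromatic carbon would restore the number of compound 3 remains open.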